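From Compound 1 to Compound 4: Replacing the Phenyl

The source may hold more compounds than are shown below. What is called first, only, known or untested is meant among the compounds shown, and "the series" means these compounds.

Measured in a functional assay on NIH3T3 cells (Mus musculus); a higher number here means that more compound is needed for the effect, a lower number that less compound is needed:
- Compound 1 `Cn1cncc1C(OCc1ccc(C#N)cc1-c1ccccc1)c1ccc(C#N)cc1`: 140 nM
- Compound 2 `Cn1cncc1C(OCc1ccc(C#N)cc1C#Cc1ccccn1)c1ccc(C#N)cc1`: > 0.1 nM
- Compound 3 `CCC/C=C/C=C/c1cc(C#N)ccc1COC(c1ccc(C#N)cc1)c1cncn1C`: 16.7 nM

Compound 1 holds the highest of the two actual numbers. The value of compound 2 is a limit and not a number. Its step therefore gives no size: a step that the limit leaves unreadable from compound 1 to compound 2. Among the compounds with values here, the nearest number is reached through an 8.4-fold lower number from compound 1 to compound 3 (0.92 log units; beyond the scatter), the only readable step bearing on this change.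

Compound 4 `Cn1cncc1C(OCc1ccc(C#N)cc1C#CC1(O)CCCCC1)c1ccc(C#N)cc1` differs from compound 1 as follows: 2-(1-hydroxycyclohexyl)ethynyl in place of phenyl on an aromatic carbon. Its entering group, 2-(1-hydroxycyclohexyl)ethynyl, has not been measured in this assay, so the readable step serves only as a rough guide to direction. A modest drop is expected, namely a 2.8-fold lower number from compound 1 to compound 4 (0.45 log units; beyond the scatter). Compound 4 is estimated at 50 nM, with an expected range from 10 nM to 250 nM.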

Compound 4, half-maximal effective concentration: 1.93 nM
The estimate for compound 4 lay 26-fold (1.41 log units) above the measured number, outside the stated range (below it).
By their numbers in this assay, from the lowest: compound 4; then compound 3; then compound 1.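

In this assay, 2-(1-hydroxycyclohexyl)ethynyl on this aromatic carbon gives a 73-fold lower number from compound 1 to compound 4 (1.86 log units; beyond the scatter), and also an 8.7-fold lower number from compound 3 to compound 4 (0.94 log units; beyond the scatter). The position therefore accepts a non-aromatic ring on a triple bond, with a hydrogen-bond donor, and the number still falls further than with hepta-1,3-dien-1-yl. Compound 2 has only a limit, so its step to compound 4 cannot be read: the limit of > 0.1 nM in this assay, at which 1 of the 4 values shown sits.

The compounds shown leave open whether the hydroxyl itself contributes to this drop. An amine in its place, or a plain cyclohexyl on the triple bond, would address that.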